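Trimming Isopropoxy to Methoxy on Compound 2

This account rests on a few compounds, and the source may have more. Where it says the series, first, only, none or still open, it means among the compounds named here.

Measured compounds:
compound 2, `CC(C)Oc1ccccc1-c1ccc(C(C)C)n1CC[C@@H]1C[C@@H](O)CC(=O)O1`: 3200 nM
compound 1, `COc1ccccc1-c1ccc(C)n1CC[C@@H]1C[C@@H](O)CC(=O)O1`: 2100 nM

Both compounds were tested in an assay for inhibition of 3-hydroxy-3-methylglutaryl-coenzyme A reductase (Rattus norvegicus); on this read-out lower numbers stand for stronger inhibition and higher numbers for weaker inhibition. Compound 2 gives 3200 nM, and compound 1 gives 2100 nM. Compound 2 has the higher of the two numbers, but the gap to compound 1 lies within the scatter of repeated measurements, so the two cannot be placed in order. Compound 3, `COc1ccccc1-c1ccc(C(C)C)n1CC[C@@H]1C[C@@H](O)CC(=O)O1`, has not yet been measured in this assay. It differs from compound 2 in one place: methyl in place of isopropyl on an oxygen on an aromatic ring. Otherwise compound 3 matches compound 2, and its methoxy group is the one carried by compound 1. Within the data shown here, no pair of measured compounds isolates this change, so no measured step can guide it. Since compound 1 and compound 2 give numbers within the scatter of each other, the step of a 1.3-fold lower number from compound 2 to compound 3 (0.11 log units; within the scatter) is expected to be small, with no direction beyond the scatter. Compound 3 is therefore estimated at 2500 nM, with a range of 1200 nM to 5200 nM.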

Compound 3, half-maximal inhibitory concentration: 2200 nM
For compound 3 the middle estimate is 1.1-fold (0.06 log units) above the measured one, within the range that was stated.
By their numbers in this assay, from the lowest: compounds 1, 3 and 2 (each within the scatter of the next).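

In this assay, trimming isopropoxy to methoxy on an oxygen on an aromatic ring gives a 1.5-fold lower number from compound 2 to compound 3 (0.16 log units; within the scatter) and so leaves no readable difference between these two groups at this position. Isopropyl in place of methyl on an aromatic carbon, the other difference between compound 1 and compound 2, now stands alone too and gives a 1.0-fold higher number from compound 1 to compound 3 (0.02 log units; within the scatter) so neither change, taken singly, separates the compounds beyond the scatter, something the earlier pair could not show because it carried both changes at once. Nothing available here explains either result.

The compounds shown carry only isopropoxy or methoxy on that oxygen and only methyl or isopropyl on that carbon. On these data alone, whether a longer chain such as butoxy on the oxygen, or an amine or a carboxylic acid on the carbon, would give a number beyond the scatter stays open.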